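From 2-carboxyethyl to 2-(cyclopropylcarbamoyl)ethenyl: working notes

A few compounds are considered here, and "the series" means these few. Any claim that something is new, unique, unknown or untested is made for them only; others in the source may bear on it.

Measured so far in a functional assay on MDA-MB-231 cells (Homo sapiens) for inhibition, read by sulforhodamine B assay, with a stated time of 72 h; on this read-out higher numbers stand for weaker inhibition of growth and lower numbers for stronger inhibition of growth:
- compound 1 `O=C(O)/C=C/c1ccncc1-c1ccc2ccccc2c1` gives > 10000 nM (a limit)
- compound 2 `O=C(O)CCc1ccncc1-c1ccc2ccccc2c1` gives > 10000 nM (a limit)

Compound 2 has > 10000 nM as a limit and no number. Both measured compounds share the limit of > 10000 nM in this assay, at which 2 of the 2 values shown sit, with no number among them. Among the measured compounds shown here, the only measured step that the two limits leave unreadable from compound 1 to compound 2 gives no size to carry over, so any expectation rests on the structural change alone. Compound 3 `O=C(/C=C/c1ccncc1-c1ccc2ccccc2c1)NC1CC1` brings 2-(cyclopropylcarbamoyl)ethenyl in place of 2-carboxyethyl on an aromatic carbon as its change. A move toward stronger inhibition of growth in this assay is expected tentatively, with another limit about as likely. The expected size is an at least 2.0-fold lower number from compound 2 to compound 3 (0.30 log units; that floor lies within the scatter) (an estimate). For compound 3 the estimated value is 5000 nM with an expected range from 800 nM to 20000 nM in this estimate.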

Compound 3, concentration for 50% growth inhibition: 8420 nM
Beside the measured number, compound 3's estimate is 1.7-fold (0.23 log units) below it; the measured number falls inside the stated range.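

In this assay, compound 3 at 8420 nM is the only compound shown with a number rather than a limit: the limit of > 10000 nM in this assay, at which 2 of the 3 values shown sit.

Replacing hydroxy with cyclopropylamino on the carbonyl carbon gives an at least 1.1-fold lower number from compound 1 to compound 3 (0.07 log units; that floor lies within the scatter), and the full change at the position opposite the ring nitrogen gives an at least 1.1-fold lower number from compound 2 to compound 3 (0.07 log units; that floor lies within the scatter). Both floors lie within the scatter, so neither step establishes a real gain.

From the compounds shown here alone, it remains open whether the ethenyl link matters for an amide at this position, as a saturated 2-(cyclopropylcarbamoyl)ethyl chain would test. Going by these compounds, how a dimethylamino or benzylamino group on the carbonyl carbon would read also remains open.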